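A few compounds are considered here, and "the series" means these few. Any claim that something is new, unique, unknown or untested is made for them only; others in the source may bear on it.

Working notes on the benzyl-linked chloropurine series. In a functional assay on ACHN cells (Homo sapiens) for cytotoxicity, read by sulforhodamine B assay, with a stated time of 48 h (on this read-out lower numbers stand for stronger inhibition of growth and higher numbers for weaker inhibition of growth), compound 1 `ClCc1ccc(Cn2cnc3c(Cl)ncnc32)cc1` gives 1280 nM. Compound 2 `ClCc1cccc(Cn2cnc3ncnc(Cl)c32)c1` gives 3540 nM in this assay. Compound 3 `ClCc1cccc(Cn2cnc3c(Cl)ncnc32)c1` gives 4070 nM in this assay, the highest of the three numbers; its value and that of compound 2 lie within the scatter of each other, whereas compound 1 sits at a lower number than compound 3 by a margin beyond the scatter.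

Compound 4 `ClCc1cccc(Cn2cnc3c(Cl)nc(Cl)nc32)c1` differs from compound 3 by chloro in place of hydrogen on an aromatic carbon. Going by the values given here, no step between measured compounds in this set exchanges hydrogen for chloro on the core, so there is nothing in the measured numbers to anchor the size of this change. The expectation for compound 4 is a step of a 1.4-fold lower number from compound 3 to compound 4 (0.13 log units; within the scatter), that is, no change beyond the scatter, with the second chloro neither clearly helping nor clearly hurting. The estimate for compound 4 in this assay is 3000 nM, with a range from 1000 nM to 9000 nM.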

Compound 4, concentration for total growth inhibition: 3710 nM
Compound 4: the middle estimate sits 1.2-fold (0.09 log units) below what was measured; low and high end bracket the measured number.
By their numbers in this assay, from the lowest: compound 1; then compounds 2, 4 and 3 (each within the scatter of the next).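

In this assay, going by these compounds alone, chloro in place of hydrogen on the aromatic carbon between two ring nitrogen atoms gives a 1.1-fold lower number from compound 3 to compound 4 (0.04 log units; within the scatter), the only step in this set between compounds that differ in one place. It shows that this position carries a chloro group, meta to the existing chloro group, without a difference beyond the scatter, so compound 3 and compound 4 cannot be told apart on this read-out. No supporting measurement bears on why this exchange is tolerated.

From the compounds shown here alone, it remains open whether an amine or a methoxy group on this same carbon would give a step beyond the scatter. Going by these compounds, it also remains open whether the same exchange of hydrogen for chloro on compound 1 would stay within the scatter.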